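Moving trifluoromethoxy on the sulfur-bound phenyl

A few compounds are considered here, and "the series" means these few. Any claim that something is new, unique, unknown or untested is made for them only; others in the source may bear on it.

Of the compounds shown here, three with a shared core have been measured in a functional assay on VCaP cells (Homo sapiens) for antiproliferative activity, read by fluorescence and propidium iodide staining, with a stated time of 96 h (a higher number here means a weaker inhibitor, a lower number a stronger inhibitor), where compound 1 (`CC(O)(CSc1cccc(C(F)(F)F)c1)C(=O)Nc1cc(C(F)(F)F)cc(C(F)(F)F)c1`) gives 9860 nM and compound 2 (`CC(O)(CSc1ccccc1C(F)(F)F)C(=O)Nc1cc(C(F)(F)F)cc(C(F)(F)F)c1`) gives 3840 nM on the same scale. Compound 3 (`CC(O)(CSc1cccc(OC(F)(F)F)c1)C(=O)Nc1cc(C(F)(F)F)cc(C(F)(F)F)c1`) gives 9290 nM in the same test. Two steps fix its standing: a 1.1-fold lower number from compound 1 to compound 3 (0.03 log units; within the scatter) places it level with the 3-(trifluoromethyl)phenyl analogue, and a 2.4-fold higher number from compound 2 to compound 3 (0.38 log units; beyond the scatter) leaves it clear of the 2-(trifluoromethyl)phenyl analogue.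

Compound 4 (`CC(O)(CSc1ccccc1OC(F)(F)F)C(=O)Nc1cc(C(F)(F)F)cc(C(F)(F)F)c1`) has not yet been measured. It carries 2-(trifluoromethoxy)phenyl in place of 3-(trifluoromethoxy)phenyl on a sulfur and is otherwise unchanged. Among the measured compounds shown here, the nearest precedent is the matching change among the trifluoromethyl analogues, a 2.6-fold lower number from compound 1 to compound 2 (0.41 log units; beyond the scatter) in this test. For the measured compounds named here, that is a single, modest step, and no measured pair carries the same change with trifluoromethoxy itself, so the precedent is only a loose guide. A step of similar or slightly smaller size toward a lower number is therefore expected, and the estimated step is a 2.1-fold lower number from compound 3 to compound 4 (0.31 log units; beyond the scatter) on that basis. For compound 4 the estimated value is 4500 nM with an expected range from 2000 nM to 9500 nM in this test.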

Compound 4, half-maximal inhibitory concentration: 2900 nM
For compound 4 the middle estimate is 1.6-fold (0.19 log units) above the measured one; the measured number falls inside the stated range.
By their numbers in this assay, from the lowest: compounds 4 and 2 (each within the scatter of the next); then compounds 3 and 1 (each within the scatter of the next).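

With compound 4, the move from 3-(trifluoromethoxy)phenyl to 2-(trifluoromethoxy)phenyl on the sulfur has its own measured step in this assay: a 3.2-fold lower number from compound 3 to compound 4 (0.51 log units; beyond the scatter) is beyond the scatter and runs in the same direction as a 2.6-fold lower number from compound 1 to compound 2 (0.41 log units; beyond the scatter) among the trifluoromethyl analogues, so the lower number with the 2-substituted phenyl is seen in both pairs shown. The step that changes both the group and its place on the ring, a 3.4-fold lower number from compound 1 to compound 4 (0.53 log units; beyond the scatter) also lies beyond the scatter, while exchanging the group alone does not, as a 1.3-fold lower number from compound 2 to compound 4 (0.12 log units; within the scatter) stays within it. Trifluoromethoxy in place of trifluoromethyl on an aromatic carbon therefore now reads as no measurable change twice over, and the two readings agree: the same change on two cores in this assay, a 1.1-fold lower number (0.03 log units; within the scatter) from compound 1 to compound 3 and a 1.3-fold lower number (0.12 log units; within the scatter) from compound 2 to compound 4, 1.2-fold (0.10 log units) apart, within the scatter of two such steps.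

These four compounds cover only trifluoromethyl and trifluoromethoxy on the sulfur-bound phenyl, so they leave open whether a methoxy group, a nitrile or an amine in their place would follow the same pattern. They also cannot say whether the lower number with the 2-substituted phenyl would survive an oxygen in place of the sulfur, or why the two positions differ at all.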